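This account rests on a few compounds, and the source may have more. Where it says the series, first, only, none or still open, it means among the compounds named here.

Measured so far in a functional assay on MCF7 cells (Homo sapiens) for cytotoxicity, read by MTT assay, with a stated time of 4 days; a higher number here means a weaker inhibitor, a lower number a stronger inhibitor:
compound 1, `C=C1C[C@]23C[C@@]1(O)CC[C@H]2c1cc(Br)c(O)c(C)c1[C@@H]3Cn1cc(-c2ccccn2)nn1`, > 20000 nM;
compound 2, `C=C1C(=O)[C@]23C[C@@]1(O)CC[C@H]2c1ccc(O)c(C)c1[C@@H]3Cn1cc(-c2ccc(C)cc2)nn1`, gives 370 nM.

For compound 1 the result is only (the limit of > 20000 nM in this assay, at which 1 of the 2 values shown sits), so the value is a limit of the assay and not a number. Among the compounds with values here, compound 2 gives a numerical value, 370 nM, but it differs from compound 1 in more than one place, so no single step between the two can be read from their values.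

Compound 3, `C=C1C[C@]23C[C@@]1(O)CC[C@H]2c1cc(Br)c(O)c(C)c1[C@@H]3Cn1cc(-c2ccc(OC)cc2)nn1`, has not yet been measured. It differs from compound 1 in one place: 4-methoxyphenyl in place of pyridin-2-yl on an aromatic carbon. Within the data shown here, no measured pair shows what this change does to this assay. Because compound 1 sits at > 20000 nM, only a limit, the size of the step can only be guessed. The estimated step of an at least 1.6-fold lower number from compound 1 to compound 3 (0.22 log units; that floor lies within the scatter) is expected to move toward a somewhat stronger inhibitor, though with wide uncertainty. Compound 3 is therefore expected near 12000 nM, with a range from 2500 nM to 40000 nM.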

Compound 3, half-maximal inhibitory concentration: > 20000 nM
Compound 3: no number, only a limit; the forecaster's own chance of this, stated with the estimate: 45%; middle value at least 1.6-fold (0.22 log units) from the limit.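

No step between compound 1 and compound 3 can be read, since the result for each is a limit of the assay and not a number: the limit of > 20000 nM in this assay, at which 2 of the 3 values shown sit.

The compounds shown leave open what 4-methoxyphenyl in place of pyridin-2-yl does in this assay.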